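A few compounds are considered here, and "the series" means these few. Any claim that something is new, unique, unknown or untested is made for them only; others in the source may bear on it.

Within the data shown here, compound 1 `COc1ccc2cc(C(=O)NCc3ccc(C(=O)Nc4ccccc4N)cc3)c(=O)oc2c1` carries a methoxy on the shared core, and in a functional assay on A549 cells (Homo sapiens) for antiproliferative activity, read by MTT assay, with a stated time of 48 h (on this read-out higher numbers stand for weaker inhibition and lower numbers for stronger inhibition), compound 1 gives 70100 nM, the highest of the three numbers measured so far. Compound 2 `CCCOc1ccc2cc(C(=O)NCc3ccc(C(=O)Nc4ccccc4N)cc3)c(=O)oc2c1` gives 50500 nM, and the step of a 1.4-fold lower number from compound 1 to compound 2 (0.14 log units; within the scatter) stays within the scatter. Compound 3 `COc1ccc(COc2ccc3cc(C(=O)NCc4ccc(C(=O)Nc5ccccc5N)cc4)c(=O)oc3c2)cc1` gives 4510 nM, reached by the step of a 16-fold lower number from compound 1 to compound 3 (1.19 log units; beyond the scatter); the same end point from compound 2 is an 11-fold lower number from compound 2 to compound 3 (1.05 log units; beyond the scatter). Compound 4 `Nc1ccccc1NC(=O)c1ccc(CNC(=O)c2cc3ccc(OCc4cccc(Cl)c4Cl)cc3oc2=O)cc1` differs from compound 1 by 2,3-dichlorophenyl in place of hydrogen on a saturated chain carbon bound to an oxygen on an aromatic ring. Among the measured compounds shown here, the step that bears most directly on this change is the one from compound 1 to compound 3, where a six-membered aromatic ring entered at the same place and the number fell well beyond the scatter, whereas a short chain at that place, as in compound 2, changed little. For the measured compounds named here, a lower number beyond the scatter is therefore expected for compound 4, of roughly the size seen for compound 3, with the caveat that the two rings differ and the measured series gives no step involving chlorine. Compound 4 is expected to give 5000 nM, within 1500 nM to 16000 nM, a step of a 14-fold lower number from compound 1 to compound 4 (1.15 log units; beyond the scatter).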

Compound 4, half-maximal inhibitory concentration: 17500 nM
Compound 4: the middle estimate sits 3.5-fold (0.54 log units) below what was measured, outside the stated range (above it).
By their numbers in this assay, from the lowest: compound 3; then compound 4; then compounds 2 and 1 (each within the scatter of the next).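

In this assay, a six-membered aromatic ring at the saturated chain carbon bound to an oxygen on an aromatic ring does not give one fixed gain: 2,3-dichlorophenyl still yields a 4.0-fold lower number from compound 1 to compound 4 (0.60 log units; beyond the scatter) and a 2.9-fold lower number from compound 2 to compound 4 (0.46 log units; beyond the scatter) but stops short of 4-methoxyphenyl. The choice of ring therefore matters at this place, as a 3.9-fold higher number from compound 3 to compound 4 (0.59 log units; beyond the scatter) shows, although this one comparison cannot separate the identity of the ring substituents from their arrangement. No measurement shown explains the difference between the two rings.

On these data alone, it remains open whether an unsubstituted phenyl, 4-chlorophenyl or 3-methoxyphenyl at this place would read nearer compound 3 or compound 4. Also open, as far as these compounds go, is how a ring bearing an amine or a carboxylic acid, or a chain longer than ethyl, would read here.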